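Removing a methoxymethyl group from compound 2

The source may report more compounds than this note shows. Statements on the series, on what has been measured and on what is new or still open speak of the compounds shown alone.

Of the compounds shown here, two have been measured so far. In a functional assay on HeLa cells (Homo sapiens) for cytotoxicity, read by MTT assay (on this read-out higher numbers stand for weaker inhibition and lower numbers for stronger inhibition), compound 1 (`COc1ccc([C@@H]2C[C@@H]2c2cc(OC)c(OC)c(OC)c2)cc1O`) gives 28 nM, and compound 2 (`COCOc1cc(C#Cc2cc(OC)c(OC)c(OC)c2)ccc1OC`) gives 26800 nM. Compound 2 therefore holds the higher of the two numbers, well beyond the scatter of repeat measurements, which makes it the weaker inhibitor of the pair.

The next structure, compound 3 (`COc1ccc(C#Cc2cc(OC)c(OC)c(OC)c2)cc1O`), comes from compound 2 by one change: hydrogen in place of methoxymethyl on an oxygen on an aromatic ring. In words, hydrogen takes the place of methoxymethyl on an oxygen on an aromatic ring, so methoxymethoxy becomes hydroxy.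

Within the data shown here, no measured pair shows this change alone, so the guidance is indirect. Compound 1 carries the same hydroxy and gives 28 nM, although its core also differs from that of compound 3. A large step toward stronger inhibition in this assay is therefore expected, beyond the scatter, though compound 3 is not expected to match compound 1. The expected change is a 54-fold lower number from compound 2 to compound 3 (1.73 log units; beyond the scatter). Compound 3 is estimated at 500 nM, with an expected range of 50 nM to 5000 nM.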

Compound 3, half-maximal inhibitory concentration: 1540 nM
For compound 3 the middle estimate is 3.1-fold (0.49 log units) below the measured one; the range from low to high includes it.
By their numbers in this assay, from the lowest: compound 1; then compound 3; then compound 2.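

Going from methoxymethoxy to hydroxy, with the rest of the molecule unchanged, gives a 17-fold lower number from compound 2 to compound 3 (1.24 log units; beyond the scatter) in this assay. Among these compounds, this is the first reading of this position on its own: compounds 1 and 2 differ in more than one place, so their gap could not show what this group contributes, whereas this step ties a large part of the inhibition seen here to what sits on this oxygen. The change does not close the whole gap, since compound 3 at 1540 nM still carries a higher number than compound 1 at 28 nM, and no evidence here explains why removing methoxymethyl has this effect.

Only hydrogen and methoxymethyl are shown on this oxygen, so it remains open whether a plain methyl, a longer chain such as ethyl, or an amine in place of the hydroxy would read closer to compound 2 or to compound 3. From the compounds shown here alone, it also remains open whether the same exchange would give a step of similar size on the core of compound 1.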